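A few compounds are considered here, and "the series" means these few. Any claim that something is new, unique, unknown or untested is made for them only; others in the source may bear on it.

Measured so far, in a functional assay on MGC-803 cells (Homo sapiens) for inhibition, read by sulforhodamine B assay; a lower number here means a stronger inhibitor, a higher number a weaker inhibitor:
- compound 1, `CCCc1ccc(NC2=CC(=O)c3nc4n(c3C2=O)[C@H]2OC[C@@H](O)[C@H]2OC4)cc1`: 1560 nM
- compound 2, `O=C1C(Nc2ccc(Br)cc2)=CC(=O)c2c1nc1n2[C@H]2OC[C@@H](O)[C@H]2OC1`: 2020 nM

The number for compound 1 and the number for compound 2 lie within the usual scatter of each other, so neither compound can be called the stronger inhibitor. Compound 3, `O=C1C=C(NC2CCCCC2)C(=O)c2c1nc1n2[C@H]2OC[C@@H](O)[C@H]2OC1`, has not been measured. It differs from compound 1 in one place: cyclohexyl in place of 4-propylphenyl on an amine nitrogen. For the measured compounds named here, no measured pair shows this change, so its effect is unknown; a modest weakening beyond the scatter is expected, a 1.8-fold higher number from compound 1 to compound 3 (0.25 log units; within the scatter). Compound 3 is therefore expected to give about 2800 nM in this assay, within a range from 900 nM to 9000 nM.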

Compound 3, half-maximal inhibitory concentration: > 8000 nM
Compound 3 gave a limit, no number; the forecaster's own chance of this, stated with the estimate: 10%; middle value at least 2.8-fold (0.45 log units) from the limit.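

The earlier compounds shown here both carry a substituted phenyl on this amine nitrogen, so they could not show whether an aromatic ring is needed there. In this assay, cyclohexyl in place of 4-propylphenyl gives an at least 5.1-fold higher number from compound 1 to compound 3 (0.70 log units; beyond the scatter), so this position does not accept every six-membered ring of carbon. The result for compound 3 is a limit, not a number: the limit of > 8000 nM in this assay, at which 1 of the 3 values shown sits.

This single change both removes the aromatic ring and drops the propyl chain, so the two cannot be separated. An unsubstituted phenyl or a 4-propylcyclohexyl on the same nitrogen would tell them apart.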